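Moving a Hydroxyl Around a Terminal Phenyl Ring

A few compounds are considered here, and "the series" means these few. Any claim that something is new, unique, unknown or untested is made for them only; others in the source may bear on it.

Compound 3 `Oc1cccc(-c2cc(-c3ccccc3OC(F)(F)F)cc(-c3ccccc3O)n2)c1` is the starting point here. In a functional assay on HCT-15 cells (Homo sapiens) for inhibition (on this read-out lower numbers stand for stronger inhibition and higher numbers for weaker inhibition), compound 3 gives 3240 nM. Compound 1 `Oc1cccc(-c2cc(-c3ccccc3F)cc(-c3cccc(O)c3)n2)c1` gives 5300 nM, a difference within the usual scatter, while compound 2 `Oc1cccc(-c2cc(-c3ccccc3C(F)(F)F)cc(-c3cccc(O)c3)n2)c1` gives 8150 nM, a gap beyond the scatter. For the measured compounds named here, the only measured step, a 1.5-fold higher number from compound 1 to compound 2 (0.19 log units; within the scatter), alters a different part of the molecule and therefore offers no direct guide. Compound 4 `Oc1cccc(-c2cc(-c3ccccc3OC(F)(F)F)cc(-c3cccc(O)c3)n2)c1` differs from compound 3 by 3-hydroxyphenyl in place of 2-hydroxyphenyl on an aromatic carbon. Going by the values given here, with no measured step touching this change, and with compounds 1 and 2 lying in a similar range, no movement beyond the scatter is expected. Compound 4 is therefore estimated at 4500 nM, within a range from 2000 nM to 10000 nM. This corresponds to an expected 1.4-fold higher number from compound 3 to compound 4 (0.14 log units; within the scatter).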

Compound 4, half-maximal inhibitory concentration: 4220 nM
Compound 4: middle estimate off by 1.1-fold (0.03 log units), on the high side; the measured number falls inside the stated range.
By their numbers in this assay, from the lowest: compounds 3, 4, 1 and 2 (each within the scatter of the next, the first and the last beyond it).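

The step of a 1.3-fold higher number from compound 3 to compound 4 (0.11 log units; within the scatter) shows that in this assay the 2-hydroxyphenyl and 3-hydroxyphenyl groups cannot be told apart at this position. Compound 4 also links the other two compounds: the step of a 1.9-fold lower number from compound 2 to compound 4 (0.29 log units; within the scatter) puts trifluoromethoxy in place of trifluoromethyl, and the step of a 1.3-fold lower number from compound 1 to compound 4 (0.10 log units; within the scatter) puts it in place of fluoro, with neither leaving the scatter. Nothing at hand explains these small differences. As far as these compounds go, whether an amine or a carboxylic acid in place of the hydroxyl would shift the number beyond the scatter remains open.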